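Ethylamino in place of chloro on the shared core

The source may hold more compounds than are shown below. What is called first, only, known or untested is meant among the compounds shown, and "the series" means these compounds.

For the measured compounds named here, compound 1 `N#Cc1c(Cl)nc(SCc2nc3ccccc3[nH]2)nc1-c1ccccc1` gives 4.46 nM in a functional assay on HL-60 cells (Homo sapiens) for cytotoxicity, read by MTT assay, with a stated time of 3 days; on this read-out lower numbers stand for stronger inhibition and higher numbers for weaker inhibition; only one other number has been measured so far, and that is compound 2 `CNc1nc(SCc2nc3ccccc3[nH]2)nc(-c2ccccc2)c1C#N`, which gives 6.57 nM in this assay. The step of a 1.5-fold higher number from compound 1 to compound 2 (0.17 log units; within the scatter) stays within the scatter, so the two compounds cannot be ranked. Compound 3 `CCNc1nc(SCc2nc3ccccc3[nH]2)nc(-c2ccccc2)c1C#N` differs from compound 1 in one place: ethylamino in place of chloro on an aromatic carbon. Going by the values given here, the single measured step that bears on this change is the replacement of chloro by methylamino, a 1.5-fold higher number from compound 1 to compound 2 (0.17 log units; within the scatter), which did not move the number beyond the scatter; no other comparison exists for an alkylamino group on this carbon. On that basis no step beyond the scatter is expected for compound 3, and the estimated step is a 1.5-fold higher number from compound 1 to compound 3 (0.16 log units; within the scatter). Compound 3 is estimated at 6.5 nM, with a range from 2.5 nM to 17 nM.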

Compound 3, half-maximal inhibitory concentration: 3.96 nM
Compound 3: middle estimate off by 1.6-fold (0.22 log units), on the high side, and the stated range covers the measured number.
By their numbers in this assay, from the lowest: compounds 3, 1 and 2 (each within the scatter of the next).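

In this assay, ethylamino on this aromatic carbon, ortho to a cyano group, gives a 1.1-fold lower number from compound 1 to compound 3 (0.05 log units; within the scatter), so a second alkylamino group now fails to separate from chloro, where only methylamino stood before. Methyl in place of hydrogen on the saturated chain carbon bound to the nitrogen gives a 1.7-fold lower number from compound 2 to compound 3 (0.22 log units; within the scatter), so the size of the alkyl group also moves the number no further than the scatter across this pair, and compound 1, compound 2 and compound 3 cannot be ranked. No evidence at hand bears on this result.

Still open, on these data alone, is whether a longer chain such as butylamino, a cyclic amine such as morpholine, or an unsubstituted amino group would step beyond the scatter on this carbon. Also open, as far as these compounds go, is whether the same flat reading would hold with another group in place of the phenyl group.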